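From Phenylsulfanyl to Phenylsulfonyl on a Shared Core

The compounds below may be only part of what the source reports. "The series", "measured", "known", "first", "only" and "open" are said of these compounds alone.

- Compound 1 `CC(C)(C)c1ccc(OCCCN2CCC(C(c3ccc(F)cc3)c3ccc(F)cc3)CC2)cc1`: 1 nM
- Compound 2 `CC(=O)Nc1ccc(OCCCN2CCC(C(c3ccc(F)cc3)c3ccc(F)cc3)CC2)cc1`: 12.6 nM
- Compound 3 `Fc1ccc(C(c2ccc(F)cc2)C2CCN(CCCSc3ccccc3)CC2)cc1`: 3.16 nM

In a functional assay (aorta) with Oryctolagus cuniculus as the target (on this read-out higher numbers stand for weaker binding and lower numbers for tighter binding), compound 3 at 3.16 nM holds the middle of the three measured numbers. Compound 4 `O=S(=O)(CCCN1CCC(C(c2ccc(F)cc2)c2ccc(F)cc2)CC1)c1ccccc1` carries phenylsulfonyl in place of phenylsulfanyl on a saturated chain carbon, three bonds along the chain from an amine nitrogen in a ring. Within the data shown here, no measured step makes this exact change. Two swaps at the same place are modest: a 3.2-fold higher number from compound 1 to compound 3 (0.50 log units; beyond the scatter) and a 4.0-fold lower number from compound 2 to compound 3 (0.60 log units; beyond the scatter). The acetamido swap is large: a 13-fold higher number from compound 1 to compound 2 (1.10 log units; beyond the scatter). Three compounds offer only a loose guide, but a modest rise seems the likeliest outcome. The expected step is a 3.2-fold higher number from compound 3 to compound 4 (0.50 log units; beyond the scatter). For compound 4 the estimate is 10 nM, with an expected range from 3 nM to 35 nM.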

Compound 4, dissociation constant: 20 nM
Beside the measured number, compound 4's estimate is 2.0-fold (0.30 log units) below it, within the range that was stated.
By their numbers in this assay, from the lowest: compound 1; then compound 3; then compounds 2 and 4 (each within the scatter of the next).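

Among these compounds, at this place on the chain, the two added oxygens on sulfur are the only change, and they give a 6.3-fold higher number from compound 3 to compound 4 (0.80 log units; beyond the scatter). Compound 4 cannot be told apart from the acetamido compound: the comparison reads a 1.6-fold higher number from compound 2 to compound 4 (0.20 log units; within the scatter). The gap to the tert-butyl compound is the widest among the compounds shown, at a 20-fold higher number from compound 1 to compound 4 (1.30 log units; beyond the scatter).

Nothing shown gives a reason for these steps. On these data alone, how a phenylsulfinyl group, with one oxygen on sulfur, or a longer chain would read at this place remains open.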